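Hydroxypyrimidinedione series: chain change at the aromatic nitrogen

The source may report more compounds than this note shows. Statements on the series, on what has been measured and on what is new or still open speak of the compounds shown alone.

Measured compounds:
Compound 1, `O=c1[nH]c2ncn(Cc3ccccc3)c2c(=O)n1O`, 10400 nM.
Compound 2, `O=c1[nH]c2ncn(CCOc3ccccc3)c2c(=O)n1O`, 10600 nM.

In an assay on isolated protein for inhibition of CCR4-NOT transcription complex subunit 7 (Homo sapiens), read by fluorescence (a higher number here means a weaker inhibitor, a lower number a stronger inhibitor), compound 2 gives 10600 nM. Compound 1 gives 10400 nM in this assay, and the two numbers lie within the scatter of each other, so neither stands apart; both are weak.

Compound 3, `CCCCOCCCn1cnc2[nH]c(=O)n(O)c(=O)c21`, is not yet measured. It differs from compound 2 by butoxymethyl in place of phenoxy on a saturated chain carbon, two bonds along the chain from an aromatic nitrogen. For the measured compounds named here, no measured step of this kind exists, and the two numbers so far show no difference when the group beyond the chain is changed. The step from compound 2 to compound 3 is therefore expected to stay within the scatter, with no direction favoured beyond it, which is what the estimated step of a 1.1-fold higher number from compound 2 to compound 3 (0.05 log units; within the scatter) means. For compound 3 the expected value in this assay is 12000 nM, within a range from 5000 nM to 35000 nM.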

Compound 3, half-maximal inhibitory concentration: 20600 nM
Estimate against measurement, compound 3: 1.7-fold (0.23 log units) below, within the range that was stated.
By their numbers in this assay, from the lowest: compounds 1, 2 and 3 (each within the scatter of the next).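

Working from the core of compound 2, in this assay butoxymethyl in place of phenoxy on a saturated chain carbon, two bonds along the chain from an aromatic nitrogen, gives a 1.9-fold higher number from compound 2 to compound 3 (0.29 log units; within the scatter). For the compounds shown here, this is the first change at this position that removes the six-membered aromatic ring, and the step stays within the scatter, so for this pair the ring is not needed to hold inhibition at this level. The data offer no measured basis for explaining this step.

The compounds shown leave open whether any group at this chain carbon can produce a step beyond the scatter, and in which direction. An amine, a carboxylic acid or a longer chain in place of butoxymethyl would test this, since the group changed here carries neither a charge nor a hydrogen-bond donor.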